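Agonist maximal response series: step from compound 3 to compound 4

A few compounds are considered here, and "the series" means these few. Any claim that something is new, unique, unknown or untested is made for them only; others in the source may bear on it.

Measured so far:
compound 1 `CCCCCCCC/C=C\CCCCCCCC(=O)OC[C@H](C)OP(=O)(O)OC[C@H](N)C(=O)O`, 11.2%
compound 2 `CCCCCCCC/C=C\CCCCCCCC(=O)O[C@H](C)COP(=O)(O)OC[C@H](N)C(=O)O`, 6.1%
compound 3 `C[C@H](COC(=O)CCc1ccccc1OCc1cccc(Oc2ccccc2)c1)OP(=O)(O)OC[C@H](N)C(=O)O`, 12.4%

In an assay on HEK293 cells for agonist activity at probable G-protein coupled receptor 34 (Mus musculus), with a stated time of 1 h (on this read-out higher numbers stand for larger maximal responses and lower numbers for smaller maximal responses), compound 3 gives 12.4%. Compound 1 gives 11.2% and compound 2 gives 6.1%; all three numbers lie within the usual scatter of one another, so no order among them can be read.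

Compound 4 `CCOC[C@H](COC(=O)CCc1ccccc1OCc1cccc(Oc2ccccc2)c1)OP(=O)(O)OC[C@H](N)C(=O)O` is not yet measured. It differs from compound 3 by ethoxy in place of hydrogen on a saturated chain carbon, two bonds along the chain from an oxygen on an unsaturated carbon. Going by the values given here, no measured pair shows this change, so nothing here tells its effect.

Among the compounds with values here, with three measured compounds all within scatter and no comparable step, no change beyond the scatter is expected, and the step of a number 0.4 percentage points lower from compound 3 to compound 4 (within the scatter) is estimated accordingly. Compound 4 is expected to give 12%, with a range from 4% to 22%.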

Compound 4, largest response reached (Emax), in percent of the reference or control that the assay uses: 12.1%
The estimate for compound 4 lay 0.1 percentage points below the measured number; measured number inside the range.
By their numbers in this assay, from the lowest: compounds 2, 1, 4 and 3 (each within the scatter of the next).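

In this assay, going by these compounds alone, ethoxy in place of hydrogen on a saturated chain carbon, two bonds along the chain from an oxygen on an unsaturated carbon, gives a number 0.3 percentage points lower from compound 3 to compound 4 (within the scatter) and is the first single-place step. At this position the series therefore tolerates ethoxy without a step beyond the scatter. Nothing available explains this result.
From the compounds shown here alone, whether an amine, a carboxylic acid or a longer chain at this position would also stay within the scatter remains open. Also open, going by these compounds, is whether any group here would give a step beyond the scatter.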